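The source may report more compounds than this note shows. Statements on the series, on what has been measured and on what is new or still open speak of the compounds shown alone.

Compound 1 `O=C1CCC(O)(c2cccc(C(F)(F)F)c2)N1`: > 200 mg/kg, a limit
Compound 2 `CN1C(=O)CCC1(O)c1cccc(C(F)(F)F)c1`: 129 mg/kg
Compound 3 `CCCN1C(=O)CCC1(O)c1cccc(C(F)(F)F)c1`: > 200 mg/kg, a limit

These three results come from a functional assay on the whole organism with Mus musculus as the target; on this read-out higher numbers stand for an effect only at larger amounts of compound and lower numbers for an effect already at smaller amounts. Compound 2 is the only one of the three with an actual number, 129 mg/kg. Compound 1 and compound 3 both sit at the limit of > 200 mg/kg in this assay, at which 2 of the 3 values shown sit, so neither gives a number.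

Compound 4 `CN1C(=O)CCC1(O)c1cccc(Cl)c1` differs from compound 2 on the aromatic ring: chloro in place of trifluoromethyl on an aromatic carbon. In words, it has chloro in place of trifluoromethyl on an aromatic carbon.

The measured steps all concern the group on the amide-type nitrogen. Methyl in place of hydrogen gives an at least 1.5-fold lower number from compound 1 to compound 2 (0.19 log units; that floor lies within the scatter). Going on to propyl gives an at least 1.5-fold higher number from compound 2 to compound 3 (0.19 log units; that floor lies within the scatter). Propyl in place of hydrogen gives a step that the two limits leave unreadable from compound 1 to compound 3. None of these steps touches the aromatic carbon, so none of them gives a size for the change in question, and the data hold no measured exchange at that carbon.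

The expectation therefore starts from compound 2 at 129 mg/kg, with no direction favoured and no shift beyond the scatter foreseen. The expected result is a 1.0-fold lower number from compound 2 to compound 4 (0.01 log units; within the scatter). For compound 4 the estimated value is 125 mg/kg, with an expected range of 65 mg/kg to 200 mg/kg.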

Compound 4, dose for half-maximal effect: 186 mg/kg
Compound 4: the middle estimate sits 1.5-fold (0.17 log units) below what was measured, and the stated range covers the measured number.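

For the compounds shown here, the exchange at the aromatic carbon is the first change here that lies away from the amide-type nitrogen, and in this assay chloro in place of trifluoromethyl gives a 1.4-fold higher number from compound 2 to compound 4 (0.16 log units; within the scatter). At this position, then, a single chlorine atom can take the place of a group of four heavy atoms with no shift that can be told apart from the usual scatter of this read-out, so compound 2 and compound 4 cannot be ranked against each other. Compound 1 and compound 3 remain limits and not numbers, which leaves this exchange as the only step in the set read between two actual numbers: the limit of > 200 mg/kg in this assay, at which 2 of the 4 values shown sit.

As far as these compounds go, it remains open whether other groups on this aromatic carbon, such as methoxy, a nitrile, a carboxylic acid or plain hydrogen, would move the number beyond the scatter, or whether any group there would bring the effect to clearly smaller amounts of compound. Also open, from the compounds shown here alone, is whether chloro would give the same picture with hydrogen, propyl or a longer chain on the amide-type nitrogen.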